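The source may hold more compounds than are shown below. What is called first, only, known or untested is meant among the compounds shown, and "the series" means these compounds.

Working notes on the series. Compound 1 `CC(C)CN1CCCC[C@H]1C(=O)Nc1cc(C(C)(C)C)on1` gives 32 ug/mL in a physicochemical assay for solubility, read by HPLC, at pH 6.8; a lower number here means a less soluble compound, a higher number a more soluble compound. Compound 2 `CC(C)(C)c1cc(NC(=O)[C@@H]2CCCCN2CC2CCOCC2)no1` gives 72 ug/mL in this assay, and the step of a 2.3-fold higher number from compound 1 to compound 2 (0.35 log units; beyond the scatter) is a modest rise. Compound 3 `CC(C)(C)c1cc(NC(=O)[C@@H]2CCCCN2C(=O)c2ccc(Cl)cc2)no1` reports < 0.1 ug/mL in this assay, which is a limit of the assay and not a number. Of the three values shown, (the limit of < 0.1 ug/mL in this assay, at which 1 of the 3 values shown sits). Compound 3 thus stands at the bottom of the series, and the steps of an at least 320-fold lower number from compound 1 to compound 3 (2.50 log units; beyond the scatter) and an at least 720-fold lower number from compound 2 to compound 3 (2.85 log units; beyond the scatter) are both large drops.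

Compound 4 `CC(C)(C)c1cc(NC(=O)[C@@H]2CCCCN2C(=O)CC2CCOCC2)no1` is not yet measured in this assay. The change from compound 3 is (oxan-4-yl)methyl in place of 4-chlorophenyl on a carbonyl carbon. Among the compounds with values here, no measured step makes this exact change. The steps of an at least 320-fold lower number from compound 1 to compound 3 (2.50 log units; beyond the scatter) and an at least 720-fold lower number from compound 2 to compound 3 (2.85 log units; beyond the scatter) show that bringing the (4-chlorophenyl)carbonyl onto the ring nitrogen removes most of the solubility, while the step of a 2.3-fold higher number from compound 1 to compound 2 (0.35 log units; beyond the scatter) shows a modest gain when an oxane ring enters. Compound 4 keeps the carbonyl on the ring nitrogen but loses the 4-chlorophenyl, so a large rise is expected, though compound 4 is not expected to reach the values of compound 1 or compound 2. The expected step of an at least 50-fold higher number from compound 3 to compound 4 (1.69 log units; beyond the scatter) is upward. Compound 4 is estimated at 5 ug/mL in this assay, within a range from 0.5 ug/mL to 40 ug/mL.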

Compound 4, solubility: 52 ug/mL
Estimate against measurement, compound 4: 10-fold (1.02 log units) below; measured number outside the range, above it.
By their numbers in this assay, from the lowest: compounds 1, 4 and 2 (each within the scatter of the next, the first and the last beyond it). At a limit, below all of these: compound 3.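

With the carbonyl kept on the ring nitrogen, (oxan-4-yl)methyl in place of 4-chlorophenyl on the carbonyl carbon gives an at least 520-fold higher number from compound 3 to compound 4 (2.71 log units; beyond the scatter) in this assay, so the very low reading of compound 3 is not shared by every carbonyl at this position. Placing ((oxan-4-yl)methyl)carbonyl on the amine nitrogen in a ring gives a 1.4-fold lower number from compound 2 to compound 4 (0.14 log units; within the scatter) and a 1.6-fold higher number from compound 1 to compound 4 (0.21 log units; within the scatter); both steps lie within the scatter, so compound 4 cannot be told apart from compound 1 or compound 2 here, although compound 4 carries a carbonyl on that nitrogen and they do not. Compound 3 sits at a limit of the assay and not at a number, so the full size of its step to compound 4 stays unknown: the limit of < 0.1 ug/mL in this assay, at which 1 of the 4 values shown sits.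

Within the data shown here, the single change on the carbonyl carbon replaces the chlorine, the aromatic ring and the chain all at once, so it does not separate their contributions; an unsubstituted phenyl or a cyclohexylmethyl on the same carbonyl carbon would begin to do so. On these data alone, how far this position tolerates other groups also stays open, for instance a carbonyl bearing a longer chain, an amine or a carboxylic acid.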